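Swapping (carboxymethyl)amino for piperidin-1-yl

The source may hold more compounds than are shown below. What is called first, only, known or untested is meant among the compounds shown, and "the series" means these compounds.

Compound 1 `CSCc1ncnc2c1ncn2[C@@H]1O[C@H](CO)[C@@H](O)[C@H]1O`: > 100000 nM (a limit)
Compound 2 `O=C(O)CNCc1ncnc2c1ncn2[C@@H]1O[C@H](CO)[C@@H](O)[C@H]1O`: > 100000 nM (a limit)

In a functional assay on Huh-7 cells (Homo sapiens) for cytotoxicity, read by MTT assay, with a stated time of 3 days (a lower number here means that less compound is tolerated, a higher number that more compound is tolerated), compound 2 gives only a limit (> 100000 nM) and no number. Both measured compounds sit at this limit (the limit of > 100000 nM in this assay, at which 2 of the 2 values shown sit). Going by the values given here, the one measured step (a step that the two limits leave unreadable from compound 1 to compound 2) has no readable size, so it offers no guide to size or direction. Compound 3 `OC[C@H]1O[C@@H](n2cnc3c(CN4CCCCC4)ncnc32)[C@H](O)[C@@H]1O` carries piperidin-1-yl in place of (carboxymethyl)amino on a saturated chain carbon bound to an aromatic carbon. No change beyond the scatter is expected (a number no higher from compound 2 to compound 3 (the limit leaves the size open)). The estimate for compound 3 is 100000 nM, with an expected range from 30000 nM to 200000 nM.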

Compound 3, half-maximal cytotoxic concentration: 87000 nM
Estimate against measurement, compound 3: 1.1-fold (0.06 log units) above; the measured number falls inside the stated range.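

In this assay compound 3 gives a true number, 87000 nM. Piperidin-1-yl on a saturated chain carbon bound to an aromatic carbon gives an at least 1.1-fold lower number from compound 2 to compound 3 (0.06 log units; that floor lies within the scatter), and in place of methylsulfanyl it gives an at least 1.1-fold lower number from compound 1 to compound 3 (0.06 log units; that floor lies within the scatter). The true size of both steps stays unknown because compound 1 and compound 2 give only limits: the limit of > 100000 nM in this assay, at which 2 of the 3 values shown sit.

On these data alone, what stays open is whether an open-chain amine such as diethylamino, or a larger ring such as azepan-1-yl, at this place would also give a number in this assay, and how that number would compare with compound 3.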